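This account rests on a few compounds, and the source may have more. Where it says the series, first, only, none or still open, it means among the compounds named here.

In a functional assay on PC-3 cells (Homo sapiens) for antiproliferative activity, read by MTT assay, with a stated time of 72 h (on this read-out lower numbers stand for stronger inhibition and higher numbers for weaker inhibition), three compounds share one core and differ in the amine-bearing chain. Compound 1 `CN(C)CCn1cccc1/C=N/NC(=O)Nc1ccc(Oc2ccnc3[nH]ccc23)c(F)c1` gives 1600 nM, compound 2 `CCN(CC)CCCn1cccc1/C=N/NC(=O)Nc1ccc(Oc2ccnc3[nH]ccc23)c(F)c1` gives 2950 nM and compound 3 `O=C(N/N=C/c1cccn1CCCN1CCCCC1)Nc1ccc(Oc2ccnc3[nH]ccc23)c(F)c1` gives 2840 nM. Compound 3 therefore stands within the usual scatter of both others. Compound 4 `CN1CCN(CCCn2cccc2/C=N/NC(=O)Nc2ccc(Oc3ccnc4[nH]ccc34)c(F)c2)CC1` differs from compound 3 at one place: 4-methylpiperazin-1-yl in place of piperidin-1-yl on a saturated chain carbon, three bonds along the chain from an aromatic nitrogen. The closest measured swaps are a 1.0-fold lower number from compound 2 to compound 3 (0.02 log units; within the scatter), a 1.8-fold higher number from compound 1 to compound 3 (0.25 log units; within the scatter) and a 1.8-fold higher number from compound 1 to compound 2 (0.27 log units; within the scatter). All three stay within the scatter, but none brings in 4-methylpiperazin-1-yl, so they guide the expectation only loosely. No change beyond the scatter is expected in this assay. The expected step is a 1.1-fold higher number from compound 3 to compound 4 (0.02 log units; within the scatter). Compound 4 is estimated at 3000 nM, with an expected range from 1300 nM to 7000 nM.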

Compound 4, half-maximal inhibitory concentration: 2190 nM
The estimate for compound 4 lay 1.4-fold (0.14 log units) above the measured number; measured number inside the range.
By their numbers in this assay, from the lowest: compounds 1, 4, 3 and 2 (each within the scatter of the next).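

Putting 4-methylpiperazin-1-yl in place of piperidin-1-yl adds a second nitrogen to the six-membered ring and gives a 1.3-fold lower number from compound 3 to compound 4 (0.11 log units; within the scatter). The swaps from the open-chain amines, a 1.3-fold lower number from compound 2 to compound 4 (0.13 log units; within the scatter) and a 1.4-fold higher number from compound 1 to compound 4 (0.14 log units; within the scatter), also stay within the scatter, so this position has now taken a ring with 2 hetero atoms without separating the four compounds. No measurement shown here offers an explanation for this result. The compounds shown leave open whether a morpholin-4-yl group, or a chain ending in a carboxylic acid instead of an amine, would give a similar number.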